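The source may hold more compounds than are shown below. What is called first, only, known or untested is meant among the compounds shown, and "the series" means these compounds.

Measured so far in an ADME assay on THP-1 cells (Homo sapiens) for cytotoxicity, read by MTT assay; on this read-out lower numbers stand for higher toxicity in this test and higher numbers for lower toxicity in this test:
- compound 1 `COc1ccc(O)c(C(=O)/C=C/c2cc(OC)c(OC)c(OC)c2)c1`: > 25000 nM
- compound 2 `COc1ccc(O)c(C(=O)/C=C/c2ccc(OC)c(OC)c2)c1`: > 50000 nM

Compound 2 stands at > 50000 nM, which is a limit of this assay and not a number. Among the measured compounds shown here, compound 1, the only other compound measured, also gives a limit, > 25000 nM.

Compound 3 `COc1ccc(/C=C/C(=O)c2cc(OC)ccc2O)cc1` differs from compound 2 by hydrogen in place of methoxy on an aromatic carbon, ortho to a methoxy group (hydrogen in place of methoxy on an aromatic carbon). For the measured compounds named here, the one measured step of the same kind is a step that the two limits leave unreadable from compound 1 to compound 2, so it offers no size to carry over. With no readable precedent, no step beyond the scatter is expected in this assay. The expected change is a number no higher from compound 2 to compound 3 (the limit leaves the size open). Compound 3 is estimated at 50000 nM, with an expected range from 20000 nM to 100000 nM.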

Compound 3, half-maximal cytotoxic concentration in the THP-1 assay: > 100000 nM
Compound 3: only a limit was reported (the forecaster's own chance of this, stated with the estimate: 70%); middle value at least 2.0-fold (0.30 log units) away from the limit.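

In the THP-1 assay, compound 2 gives > 50000 nM, which is a limit and not a number. In the THP-1 assay, compound 3 gives > 100000 nM, which is also a limit and not a number. No step can be read between these two compounds. The compounds shown leave open where any of them would register a cytotoxic concentration in the THP-1 assay, and whether hydrogen in place of methoxy on an aromatic carbon changes it at all. In a physicochemical assay for lipophilicity (on this read-out lower numbers stand for lower lipophilicity and higher numbers for higher lipophilicity), compound 2 gives 3.52 and compound 3 gives 3.87, and the partition coefficient shows a number 0.35 log units higher from compound 2 to compound 3 (beyond the scatter).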